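Fluoro for Methyl Where Compound 3 Sits at a Limit

The source may report more compounds than this note shows. Statements on the series, on what has been measured and on what is new or still open speak of the compounds shown alone.

Compound 1 `C=C1CCC(c2csc(/C=C(\C)C(N)=O)c2)CC1` gives 8470 nM in a functional assay on MCF7 cells (Homo sapiens) for cytotoxicity, read by CCK-8 assay, with a stated time of 24 h; a higher number here means a weaker inhibitor, a lower number a stronger inhibitor.
Compound 2 `C/C(=C\c1cc(C2=CCCC2)co1)C(N)=O` gives 15000 nM in this assay.
Compound 3 `C/C(=C\c1ccc(-c2ccc(C)cc2)o1)C(N)=O` gives only a limit in this assay, > 50000 nM.

Compounds 1 and 2 show values that lie within the usual scatter of each other, so neither can be called the stronger of the two. Compound 3 is different in kind: its result is not a number but a limit of the assay, (the limit of > 50000 nM in this assay, at which 1 of the 3 values shown sits), so compound 3 stands at the weak end of what the assay can report, and how far beyond that edge it lies is not known.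

Compound 4 `C/C(=C\c1ccc(-c2ccc(F)cc2)o1)C(N)=O` is the next compound to be measured. It differs from compound 3 only in one spot: fluoro in place of methyl on an aromatic carbon. For the measured compounds named here, no pair of measured compounds here differs in such a way, so there is no measured step to lean on, and the expectation rests on the limit of compound 3 alone. A change of one small group for another at the same place is expected to move potency little, and from a starting point that is itself only a limit, compound 4 is expected to remain weak. The step from compound 3 to compound 4 is estimated at a step that the limit leaves unreadable from compound 3 to compound 4. Compound 4 is therefore expected at about 60000 nM, with a range from 20000 nM to 200000 nM, and a real chance that the assay again reports only a limit.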

Compound 4, half-maximal inhibitory concentration: 970 nM
For compound 4 the middle estimate is 62-fold (1.79 log units) above the measured one; measured number below the stated range.
By their numbers in this assay, from the lowest: compound 4; then compounds 1 and 2 (each within the scatter of the next). At a limit, above all of these: compound 3.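

In this assay, for the compounds shown here, no two earlier compounds differed in only one place, so no single change could be read; now fluoro in place of methyl, on an aromatic carbon para to a large group, gives an at least 51-fold lower number from compound 3 to compound 4 (1.71 log units; beyond the scatter). This position is therefore sensitive to a very small change: one heavy atom is exchanged for one heavy atom, with no ring, hydrogen-bond donor, hydrogen-bond acceptor or net charge entering or leaving. The full size of the step remains unknown, since one end of it is not a number but a limit: the limit of > 50000 nM in this assay, at which 1 of the 4 values shown sits.

The compounds shown leave open whether the lower number comes from the presence of fluoro or simply from the loss of methyl, since none of them carries a bare hydrogen, a chloro group, a methoxy group or an amine at this place. They also leave open whether the same exchange would have a similar effect on the core of compound 1 or compound 2, since neither compound carries methyl or fluoro on an aromatic carbon.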